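This account rests on a few compounds, and the source may have more. Where it says the series, first, only, none or still open, it means among the compounds named here.

Working notes on the thienopyrimidine-free description: the shared core of compound 1 `C#Cc1cccc(Nc2ncnc3sc(NC(=O)/C=C/c4ccccc4)cc23)c1` carries a cinnamamide and an anilino group. Among the measured compounds shown here, in a functional assay on A549 cells (Homo sapiens) for antiproliferative activity, read by MTT assay, with a stated time of 48 h (a lower number here means a stronger inhibitor, a higher number a weaker inhibitor), compound 1 gives 10100 nM, the lowest of the three numbers measured so far. Compound 2 `O=C(/C=C/c1ccccc1)Nc1cc2ncnc(Nc3cc(Cl)cc(Cl)c3)c2s1` gives 12500 nM in this assay, which lies within the scatter of compound 1. Compound 3 `COc1ccc(/C=C/C(=O)Nc2cc3ncnc(Nc4ccc(F)c(Cl)c4)c3s2)cc1`, which carries both a methoxy on the cinnamamide and the 3-chloro-4-fluorophenyl group, gives 22700 nM in this assay, a gap to compound 1 that is beyond the scatter. No pair among these three differs in one place only, so no single step has been measured.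

Compound 4 `O=C(/C=C/c1ccccc1)Nc1cc2c(Nc3ccc(F)c(Cl)c3)ncnc2s1` is the next compound: 3-chloro-4-fluorophenyl in place of 3-ethynylphenyl on a nitrogen on an aromatic ring. The same anilino group is present in compound 3, though compound 3 also carries the methoxy group, so the comparison is not a clean one. Taking compound 1 at 10100 nM and compound 3 at 22700 nM as the two anchors, the number for compound 4 is expected to rise modestly, with the step of a 1.5-fold higher number from compound 1 to compound 4 (0.17 log units; within the scatter) estimated to stay close to the scatter and possibly not beyond it. Compound 4 is therefore expected to give about 15000 nM in this assay, in a range from 7000 nM to 32000 nM.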

Compound 4, half-maximal inhibitory concentration: 11200 nM
The estimate for compound 4 lay 1.3-fold (0.13 log units) above the measured number; the range from low to high includes it.
By their numbers in this assay, from the lowest: compounds 1, 4, 2 and 3 (each within the scatter of the next, the first and the last beyond it).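

Among the compounds shown here, replacing 3-ethynylphenyl with 3-chloro-4-fluorophenyl on a nitrogen on an aromatic ring gives the first single step, and in this assay it is a 1.1-fold higher number from compound 1 to compound 4 (0.04 log units; within the scatter) and lies within the scatter, so this position accepts the exchange with no readable change in the antiproliferative number. Compound 4 has no triple bond outside aromatic rings and gives 11200 nM in this assay, so within this pair the triple bond of the 3-ethynylphenyl group is not required for a number at this level. No measurement is available that bears on why the two groups read alike.

Going by these compounds, both groups compared here are phenyl rings carrying small substituents on the aromatic nitrogen, so it remains open whether an amine such as dimethylamino or a carboxylic acid on that ring, or a longer chain in place of the ring, would move the number beyond the scatter. On these data alone, it is also open whether the same exchange would read alike with the unsubstituted cinnamamide replaced, for example by a morpholine amide.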